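Variation at the thiocarbonyl carbon across four compounds

The source may report more compounds than this note shows. Statements on the series, on what has been measured and on what is new or still open speak of the compounds shown alone.

Compounds 1, 2 and 3 share one core and differ only in the amine on the thiocarbonyl carbon. In a functional assay on A-375 cells (Homo sapiens) for antiproliferative activity, read by CCK-8 assay, with a stated time of 72 h, tested at 2 uM (on this read-out lower numbers stand for a weaker effect and higher numbers for a stronger effect at the one concentration tested), compound 1 `Nc1ccccc1NC(=O)c1ccc(CSC(=S)N2CCc3ccccc32)cc1` gives 25.7%. Compound 2 `CN1CCN(C(=S)SCc2ccc(C(=O)Nc3ccccc3N)cc2)CC1` gives 36.6%, and compound 3 `CN(Cc1ccncc1)C(=S)SCc1ccc(C(=O)Nc2ccccc2N)cc1` gives 31.4%. Compound 3 stands second highest of the three, and its gaps to compound 2 and to compound 1 are both within the scatter. The step of a number 10.9 percentage points higher from compound 1 to compound 2 (beyond the scatter) is the only one beyond the scatter; a number 5.7 percentage points higher from compound 1 to compound 3 (within the scatter) and a number 5.2 percentage points lower from compound 2 to compound 3 (within the scatter) are both within it.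

Compound 4 `Nc1ccccc1NC(=O)c1ccc(CSC(=S)N2CCCC2)cc1` is not yet measured. It differs from compound 3 as follows: pyrrolidin-1-yl in place of methyl((pyridin-4-yl)methyl)amino on a thiocarbonyl carbon. Pyrrolidin-1-yl, a five-membered non-aromatic ring, is nearer in kind to the 4-methylpiperazin-1-yl of compound 2 and the 2,3-dihydro-1H-indol-1-yl of compound 1 than to the open amine of compound 3, and the three measured values span a narrow band. Among the compounds with values here, no measured step involves pyrrolidin-1-yl. The step of a number 0.4 percentage points lower from compound 3 to compound 4 (within the scatter) is therefore expected to lie within the scatter, with no firm direction. Compound 4 is estimated at 31% in this assay, with a range from 19% to 44%.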

Compound 4, a percentage reported as inhibition, at one concentration (the size of the read-out at that concentration, not a potency): 30.2%
Beside the measured number, compound 4's estimate is 0.8 percentage points above it, and the stated range covers the measured number.
By their numbers in this assay, from the lowest: compounds 1, 4, 3 and 2 (each within the scatter of the next, the first and the last beyond it).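

In this assay the pyrrolidin-1-yl group on the thiocarbonyl carbon cannot be separated from any of the other three amines, with a number 1.2 percentage points lower from compound 3 to compound 4 (within the scatter) and a number 6.4 percentage points lower from compound 2 to compound 4 (within the scatter) and a number 4.5 percentage points higher from compound 1 to compound 4 (within the scatter) as the steps. The aromatic ring and the hydrogen-bond acceptor that leave with methyl((pyridin-4-yl)methyl)amino are therefore not required for a read-out of this size at this position, and a small saturated ring does as well as the larger amines at the one concentration tested. Nothing available accounts for this flat response.

As far as these compounds go, it remains open whether a diethylamino group or a morpholin-4-yl group on the thiocarbonyl carbon would stay in the same band. Also open, from the compounds shown here alone, is whether an unsubstituted amino group there would leave the read-out unchanged.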